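The source may report more compounds than this note shows. Statements on the series, on what has been measured and on what is new or still open speak of the compounds shown alone.

Measured so far in a physicochemical assay for lipophilicity; on this read-out higher numbers stand for higher lipophilicity and lower numbers for lower lipophilicity:

compound 1 `CC#CCOC(=O)/C=C(C)/C=C/CC(C)CCCC(C)C`: 6.4
compound 2 `COC(C)(C)CCCC(C)C/C=C/C(C)=C/C(=O)OCCC(C)C`: 7.03

Compound 2 stands highest of these two numbers; its nearest neighbour is compound 1, whose value lies lower by a gap beyond the usual scatter. Going by the values given here, no pair of measured compounds differing in a single place is available, so nothing measured speaks directly to the next change.

Compound 3 `C=CCSC(=O)/C=C(C)/C=C/CC(C)CCCC(C)(C)OC` differs from compound 2 as follows: allylsulfanyl in place of isopentyloxy on a carbonyl carbon.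

Among the compounds with values here, no measured step shows this change. For compound 3 a modest downward step a number 0.43 log units lower from compound 2 to compound 3 (beyond the scatter) in this assay is expected, about the size of the scatter. Compound 3 is estimated at 6.6, within a range of 6 to 7.2.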

Compound 3, partition coefficient: 6.77
For compound 3 the middle estimate is 0.17 log units below the measured one; low and high end bracket the measured number.
By their numbers in this assay, from the lowest: compound 1; then compounds 3 and 2 (each within the scatter of the next).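

In this assay, allylsulfanyl in place of isopentyloxy on a carbonyl carbon gives a number 0.26 log units lower from compound 2 to compound 3 (within the scatter), so at this position a swap of the six-heavy-atom chain for the four-heavy-atom, sulfur-linked one leaves the read-out within the scatter. Going by these compounds alone, this is the first single-place step. Nothing at hand explains the size of this step.

On these data alone, whether an amine on this carbonyl carbon or a longer chain on the sulfur would stay within the scatter remains open. As far as these compounds go, whether the step carries over to the core of compound 1 also remains open.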